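The source may hold more compounds than are shown below. What is called first, only, known or untested is meant among the compounds shown, and "the series" means these compounds.

Working notes on the series, all read in an ADME assay on L6 cells (Rattus norvegicus) for cytotoxicity, read by resazurin assay, with a stated time of 70 h; on this read-out lower numbers stand for stronger inhibition and higher numbers for weaker inhibition. Compound 1 (`CC(=O)Oc1ccc2c(c1)C(C)=CC(C)(C)N2Cc1ccccc1`) gives 24000 nM, compound 2 (`CC(=O)Oc1ccc2c(c1)C(C)=CC(C)(C)N2Cc1ccc(Cl)cc1`) gives 22000 nM, and compound 3 (`CC(=O)Oc1ccc2c(c1)C(C)=CC(C)(C)N2Cc1ccc(Cl)c(Cl)c1`) gives 28000 nM. Compound 1 therefore stands within the scatter of both others, and the three values cannot be ranked.

Compound 4 (`CC(=O)Oc1ccc2c(c1)C(C)=CC(C)(C)N2Cc1cccc(C(F)(F)F)c1`) keeps the core of compound 1 and differs from it in a single place: trifluoromethyl in place of hydrogen on an aromatic carbon. This is trifluoromethyl in place of hydrogen on an aromatic carbon, meta to a large group.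

The closest evidence comes from the chloro replacements on an aromatic carbon: a 1.1-fold lower number from compound 1 to compound 2 (0.04 log units; within the scatter) and a 1.3-fold higher number from compound 2 to compound 3 (0.10 log units; within the scatter). The full change from phenyl to 3,4-dichlorophenyl gives a 1.2-fold higher number from compound 1 to compound 3 (0.07 log units; within the scatter). Going by the values given here, all three steps stay within the scatter, although none of the measured compounds carries trifluoromethyl, so this evidence is indirect. On that basis, no shift beyond the scatter is expected in this assay, in either direction. The expected step is a 1.1-fold lower number from compound 1 to compound 4 (0.04 log units; within the scatter), which would stay within the scatter. For compound 4 the estimated value is 22000 nM, with an expected range of 11000 nM to 45000 nM.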

Compound 4, half-maximal inhibitory concentration: 27000 nM
For compound 4 the middle estimate is 1.2-fold (0.09 log units) below the measured one; the measured number falls inside the stated range.
By their numbers in this assay, from the lowest: compounds 2, 1, 4 and 3 (each within the scatter of the next).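

In this assay, trifluoromethyl in place of hydrogen on an aromatic carbon, meta to a large group, gives a 1.1-fold higher number from compound 1 to compound 4 (0.05 log units; within the scatter) and thus leaves compound 4 indistinguishable from compound 1. Until now, the single-place substitutions on this ring involved only chloro; this step shows that a group of 4 heavy atoms, made up of carbon and fluorine, can also enter at this place without a shift beyond the scatter. Compounds 2, 3 and 4 now all stand within the scatter of compound 1, so none of the three substituted rings separates from the unsubstituted phenyl ring, and no evidence shown here bears on the reason for this.

As far as these compounds go, whether a group of a different kind on this ring, such as an amine or a carboxylic acid, would move the number beyond the scatter remains open. Also open, from the compounds shown here alone, is whether a change elsewhere in the shared core, such as a longer chain in place of the acetyl group, would do so.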